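Aryl Exchange on the Amide Nitrogen: Efficacy Outlook

The source may hold more compounds than are shown below. What is called first, only, known or untested is meant among the compounds shown, and "the series" means these compounds.

compound 1 `CCc1cccc(NC(=O)CN2CCC(c3cccc[n+]3[O-])CC2)c1` — 62%
compound 2 `Cc1cc(C(=O)NCN2CCC(c3cccc[n+]3[O-])CC2)ccc1F` — 67%

In a functional assay on HEK293 cells for agonist activity at D(4) dopamine receptor (Homo sapiens), read by FLIPR (on this read-out lower numbers stand for smaller maximal responses and higher numbers for larger maximal responses), compound 1 gives 62%, the lower end of the two numbers, yet compound 2 at 67% lies within the scatter of it, so the two cannot be ranked. Compound 3 `O=C(CN1CCC(c2cccc[n+]2[O-])CC1)Nc1ccc(F)cc1F` is not yet measured; it differs from compound 1 by 2,4-difluorophenyl in place of 3-ethylphenyl on an amide-type nitrogen. Within the data shown here, no step between measured compounds is available, so nothing shows how this exchange acts. In this assay compound 3 is expected to give 62% (range 45% to 78%), with a step of no change at the digits printed from compound 1 to compound 3 (within the scatter) that is estimated to stay within the scatter.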

Compound 3, largest response reached (reported as efficacy), in percent of the reference or control that the assay uses: 74%
Compound 3: the middle estimate sits 12 percentage points below what was measured; measured number inside the range.
By their numbers in this assay, from the lowest: compounds 1, 2 and 3 (each within the scatter of the next, the first and the last beyond it).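

The exchange of 3-ethylphenyl for 2,4-difluorophenyl on the amide-type nitrogen shows up in this assay and gives a number 12 percentage points higher from compound 1 to compound 3 (beyond the scatter) as the first step readable at this position. The maximal response therefore depends on which aryl group sits on this nitrogen, even though both groups count the same number of heavy atoms. Nothing available bears on why the response moves. From the compounds shown here alone, it remains open whether a plain phenyl, a 4-fluorophenyl or a 4-methoxyphenyl would give a similar response, and whether the step comes from the loss of the ethyl group or from the entry of the fluorines.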